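A few compounds are considered here, and "the series" means these few. Any claim that something is new, unique, unknown or untested is made for them only; others in the source may bear on it.

Measured compounds in a functional assay on ileum (strain Hartley) for agonist activity at 5-hydroxytryptamine receptor 3A (Cavia porcellus); on this read-out lower numbers stand for lower potency and higher numbers for higher potency (the scale is a negative logarithm):
- compound 1 `COc1cc(Cl)cc2nc(N3CCN(C)CC3)oc12` gives 6.16
- compound 2 `CCOC(=O)c1ccc2oc(N3CCN(C)CC3)nc2c1` gives < 4
- compound 3 `Cc1cc(C)c2oc(N3CCN(C)CC3)nc2c1` gives 6.32

Compound 2 stands apart from the other two: its value in this assay is a limit of the assay and not a number, which is noted as the limit of < 4 in this assay, at which 1 of the 3 values shown sits. Compound 1 and compound 3, whose values sit within the usual scatter of each other, both show measurable potency on the shared core.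

Compound 4 `CCc1ccc2oc(N3CCN(C)CC3)nc2c1` has not yet been measured. It differs from compound 2 in one place: ethyl in place of ethoxycarbonyl on an aromatic carbon. Going by the values given here, no measured pair shows this change directly, so the expected size of the step rests on the other compounds. Compound 3, which carries alkyl groups on the same core, gives 6.32, and compound 4 is therefore expected to sit higher, by a step of a number at least 2.00 log units higher from compound 2 to compound 4 (beyond the scatter). The estimate for compound 4 in this assay is 6, expected to lie between 5.2 and 6.7.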

Compound 4, negative logarithm of the half-maximal effective concentration: < 4
Compound 4 was reported as a limit; the forecaster's own chance of this, stated with the estimate: 10%; middle value at least 2.00 log units away from the limit.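

Compound 2 and compound 4 are each reported only as a limit and not as a number, so no step between them can be read: the limit of < 4 in this assay, at which 2 of the 4 values shown sit.

The compounds shown leave open how far ethyl in place of ethoxycarbonyl on an aromatic carbon changes potency on the shared core.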